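This account rests on a few compounds, and the source may have more. Where it says the series, first, only, none or still open, it means among the compounds named here.

Measured so far in a functional assay on A549 cells (Homo sapiens) for antiproliferative activity, read by MTT assay, with a stated time of 48 h; on this read-out higher numbers stand for weaker inhibition and lower numbers for stronger inhibition:
Compound 1, `COc1ccc(-c2cn3cc(C4=CCN(C(=O)c5ccc(Cl)cc5)CC4)ccc3n2)cc1OC`, gives 8970 nM.
Compound 2, `COc1ccc(-c2cn3cc(C4=CCN(C(=O)c5cccc(C(F)(F)F)c5)CC4)ccc3n2)cc1OC`, gives 3690 nM.

Within the data shown here, compound 2 stands with the lowest of the two numbers, and the only measured step, a 2.4-fold lower number from compound 1 to compound 2 (0.39 log units; beyond the scatter), separates it from compound 1. That step exchanges one aromatic group for another on a carbonyl carbon. Compound 3, `COc1ccc(-c2cn3cc(C4=CCN(S(=O)(=O)C5CCCC5)CC4)ccc3n2)cc1OC`, differs from compound 2 in a different way: cyclopentylsulfonyl in place of (3-(trifluoromethyl)phenyl)carbonyl on an amine nitrogen in a ring. Here the aromatic ring and its carbonyl leave altogether, and a five-membered non-aromatic ring on a sulfonyl group enters at the amine nitrogen in the ring. Among the measured compounds shown here, the one measured step does not bear directly on this change; it shows only that trading one aromatic group for another shifts the number by a modest amount. For the measured compounds named here, no measured compound carries a sulfonyl group or a non-aromatic ring at this nitrogen, so nothing anchors the direction of the step. Compound 3 is therefore expected to remain near compound 2, with the step of a 1.4-fold higher number from compound 2 to compound 3 (0.13 log units; within the scatter) not expected to reach beyond the scatter, though the uncertainty is wide. The estimate for compound 3 in this assay is 5000 nM, between 1500 nM and 20000 nM.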

Compound 3, half-maximal inhibitory concentration: 6470 nM
Estimate against measurement, compound 3: 1.3-fold (0.11 log units) below; the measured number falls inside the stated range.
By their numbers in this assay, from the lowest: compounds 2, 3 and 1 (each within the scatter of the next, the first and the last beyond it).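

Among these compounds, until now, the only change seen at this amine nitrogen in a ring was one aromatic group on a carbonyl exchanged for another. Compound 3 shows that in this assay the aromatic ring and its carbonyl can both give way to cyclopentylsulfonyl with a 1.8-fold higher number from compound 2 to compound 3 (0.24 log units; within the scatter) and with a 1.4-fold lower number from compound 1 to compound 3 (0.14 log units; within the scatter) as well, so neither step separates compound 3 from its partner. Among these three compounds, then, an aromatic ring on a carbonyl is not needed for a number in this range, although no measurement at hand explains the result.

As far as these compounds go, the sulfonyl group and the cyclopentyl ring entered together, so the contribution of each remains unknown; cyclopentylcarbonyl or 3-(trifluoromethyl)phenylsulfonyl at this nitrogen would pull the two apart. Also open, from the compounds shown here alone, is how the number would respond to a smaller or quite different group here, such as a simple acetyl group, a longer alkyl chain, or a ring that carries an amine or a carboxylic acid.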